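Ester in Place of Chloro: Expecting Weak Inhibition Still

A few compounds are considered here, and "the series" means these few. Any claim that something is new, unique, unknown or untested is made for them only; others in the source may bear on it.

Compound 1 `CC(=O)N(c1nc(CCl)cs1)N(C(C)=O)S(=O)(=O)c1ccc(C)cc1` was tested in a functional assay on DU-145 cells (Homo sapiens) for inhibition, read by XTT assay, with a stated time of 72 h; a higher number here means a weaker inhibitor, a lower number a stronger inhibitor. In that test compound 1 gives only a limit, > 62300 nM, so no exact number is known for it. Compound 2 `CC(=O)c1sc(N(C(C)=O)N(C(C)=O)S(=O)(=O)c2ccc(C)cc2)nc1C` gives 53500 nM in this assay. The step of an at least 1.1-fold lower number from compound 1 to compound 2 (0.06 log units; that floor lies within the scatter) lies within the scatter, so exchanging the group on the amide-type nitrogen left the weak inhibition in place. Compound 3 `CCOC(=O)Cc1csc(N(C(C)=O)N(C(C)=O)S(=O)(=O)c2ccc(C)cc2)n1` carries ethoxycarbonyl in place of chloro on a saturated chain carbon bound to an aromatic carbon. Among the compounds with values here, the only measured step concerns a different position, and the measured compounds are both weak. Compound 3 is therefore expected to give 70000 nM, with a range from 30000 nM to 160000 nM, in this assay. This corresponds to an expected step that the limit leaves unreadable from compound 1 to compound 3.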

Compound 3, half-maximal inhibitory concentration: 46400 nM
For compound 3 the middle estimate is 1.5-fold (0.18 log units) above the measured one, and the stated range covers the measured number.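

At this position, ethoxycarbonyl in place of chloro gives an at least 1.3-fold lower number from compound 1 to compound 3 (0.12 log units; that floor lies within the scatter). Within the data shown here, the earlier step concerned a different position, so this shows for the first time that the larger group with its two hydrogen-bond acceptors can stand on the saturated chain carbon without any change beyond the scatter, and compound 3 remains a weak inhibitor. Compound 1 is only a limit, so the true size of the step cannot be read because of it: the limit of > 62300 nM in this assay, at which 1 of the 3 values shown sits.

As far as these compounds go, what an amine or a carboxylic acid on this chain carbon would do remains open. So does whether any group here could give clearly stronger inhibition than compound 3.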